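The source may report more compounds than this note shows. Statements on the series, on what has been measured and on what is new or still open speak of the compounds shown alone.

Of the compounds shown here, three have been measured in a functional assay on the whole organism (strain albino) for inhibition, with Rattus norvegicus as the target, read by paw edema, with stated times of 30 min and 2 h, at a dose of 100 mg/kg by the oral route; on this read-out lower numbers stand for less inhibition and higher numbers for more inhibition at the one dose given (going by the name of the read-out). Compound 1 `Nc1ccc(C(=O)/C=C/c2ccc(Cl)cc2)cc1` gives 50%, and compound 2 `O=C(CBr)Nc1ccc(C(=O)/C=C/c2ccc(Cl)cc2)cc1`, in which a (bromomethyl)carbonyl replaces the hydrogen on the ring nitrogen, gives 52%, a change of a number 2 percentage points higher from compound 1 to compound 2 (within the scatter). Compound 3 `O=C(CBr)Nc1ccc(C(=O)/C=C/c2ccco2)cc1` carries a furan-2-yl instead of the 4-chlorophenyl and gives 37%, the lowest of the three numbers, the drop being a number 15 percentage points lower from compound 2 to compound 3 (beyond the scatter). Compound 4 `CC(O[N+](=O)[O-])C(=O)Nc1ccc(C(=O)/C=C/c2ccco2)cc1` differs from compound 3 only at the carbonyl carbon bound to the amide-type nitrogen: 1-(nitrooxy)ethyl in place of bromomethyl on a carbonyl carbon. Within the data shown here, only the step from compound 1 to compound 2 touches this end of the molecule, and it was within the scatter, so adding a group on the nitrogen mattered little there; the step from compound 2 to compound 3 concerned the other end and does not bear on this change. Among the measured compounds shown here, no measured step swaps one group for another on the carbonyl carbon, so the direction is uncertain. For compound 4 the expected value is therefore close to that of compound 3, at 40% with a range from 28% to 52%. This estimate means a step of a number 3 percentage points higher from compound 3 to compound 4 (within the scatter), expected to stay within the scatter.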

Compound 4, a percentage reported as inhibition, in the whole organism at one dose (the size of the read-out at that dose, not a potency): 48%
For compound 4 the middle estimate is 8 percentage points below the measured one; low and high end bracket the measured number.
By their numbers in this assay, from the lowest: compound 3; then compounds 4, 1 and 2 (each within the scatter of the next).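

In this assay, putting 1-(nitrooxy)ethyl in place of bromomethyl on a carbonyl carbon whose other neighbour is the amide-type nitrogen gives a number 11 percentage points higher from compound 3 to compound 4 (beyond the scatter), so the group held on this carbonyl carbon can move the read-out. Among these compounds, the only earlier step at this end of the molecule, a number 2 percentage points higher from compound 1 to compound 2 (within the scatter), added the whole bromoacetyl unit to the nitrogen of a compound carrying 4-chlorophenyl; the new step instead exchanges one group for another on the carbonyl carbon, in a compound carrying furan-2-yl. The entering group has 6 heavy atoms against 2 and 3 hydrogen-bond acceptors against 0, but no measurement shown links either difference, or the loss of bromine, to the higher number.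

Going by these compounds, it remains open whether the same exchange would also raise the number on compound 2, which carries 4-chlorophenyl, as this step has been read only with furan-2-yl. A plain ethyl or a 1-hydroxyethyl group on the same carbonyl carbon would help show whether the nitrooxy part matters or the chain alone is enough.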